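The source may hold more compounds than are shown below. What is called first, only, known or untested is meant among the compounds shown, and "the series" means these compounds.

In a functional assay on the whole organism with Rattus norvegicus as the target, at a dose of 20 mg/kg by the oral route (a higher number here means more inhibition at the dose given (going by the name of the read-out), a lower number less inhibition), compound 1 `O=C(/C=C1\CCc2ccc(F)cc21)NCC1CC1` gives 0%. That is the lowest of the two numbers recorded so far. The nearest comparison, compound 2 `NC(=O)/C=C1\CCc2c(Cl)cccc21`, gives 35%, a gap that lies beyond the usual scatter of this kind of measurement; the two compounds differ in more than one place, so the gap cannot be tied to any single change. Compound 3 `CNC(=O)/C=C1\CCc2ccc(F)cc21` has not been tested. It differs from compound 1 in one place only: hydrogen in place of cyclopropyl on a saturated chain carbon bound to an amide-type nitrogen. For the measured compounds named here, no pair of tested compounds shows what this change does on its own. Since compound 1 gives 0%, a fall is hardly possible and a rise is the more likely direction. The step is expected to be small, a number 15 percentage points higher from compound 1 to compound 3 (beyond the scatter), and may not exceed the scatter. Compound 3 is therefore estimated to give 15%, with a likely range from 0% to 40%.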

Compound 3, a percentage reported as inhibition, in the whole organism at one dose (the size of the read-out at that dose, not a potency): 45%
Estimate against measurement, compound 3: 30 percentage points below, and the stated range ends below it.
By their numbers in this assay, from the lowest: compound 1; then compounds 2 and 3 (each within the scatter of the next).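

With the rest of compound 1 kept whole, putting hydrogen in place of cyclopropyl on a saturated chain carbon bound to an amide-type nitrogen gives a number 45 percentage points higher from compound 1 to compound 3 (beyond the scatter) in this assay. For the compounds shown here, this is the first reading of a single change, and it shows that this one group can separate a compound with no recorded inhibition from one with clear inhibition at the dose given. Nothing available explains why the step is this large.

Going by these compounds, whether the loss in compound 1 comes from the cyclopropyl ring itself or simply from the extra carbons remains open, and an ethyl or a longer straight chain at this place would help to tell them apart. Also open, on these data alone, is how a hydroxyethyl group or a chain carrying an amine would behave here.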